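Swapping a triazole diol chain for a piperazinylpropyl chain

The source may hold more compounds than are shown below. What is called first, only, known or untested is meant among the compounds shown, and "the series" means these compounds.

Three compounds share one core, an N-oxide-bearing tetracyclic quinone, and differ only in the group carried on the aromatic nitrogen. Compound 1 `CN1CCN(CCCCCn2c3c(c4ccccc42)C(=O)c2c[n+]([O-])c4ccccc4c2C3=O)CC1` carries a long basic chain; in a functional assay on A-375 cells (Homo sapiens) for cytotoxicity, read by MTT assay, with a stated time of 72 h (a higher number here means a weaker inhibitor, a lower number a stronger inhibitor), compound 1 gives 1710 nM. Compound 2 `O=C1c2c[n+]([O-])c3ccccc3c2C(=O)c2[nH]c3ccccc3c21` carries only hydrogen there and in this assay compound 2 gives 660 nM. Compound 3 `O=C1c2c[n+]([O-])c3ccccc3c2C(=O)c2c1c1ccccc1n2Cc1cn(CC(O)CO)nn1` carries a triazole with a dihydroxypropyl group; in this assay compound 3 gives 440 nM, the lowest number of the three, though its gap to compound 2 lies within the scatter: a 1.5-fold lower number from compound 2 to compound 3 (0.18 log units; within the scatter). Only its gap to compound 1 is clear: a 3.9-fold lower number from compound 1 to compound 3 (0.59 log units; beyond the scatter).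

Compound 4 `O=C1c2c[n+]([O-])c3ccccc3c2C(=O)c2c1c1ccccc1n2CCCCN1CCNCC1` is not yet measured. Its change from compound 3 is 3-(piperazin-1-yl)propyl in place of 1-(2,3-dihydroxypropyl)-1H-1,2,3-triazol-4-yl on a saturated chain carbon bound to an aromatic nitrogen. This largely reverses the step from compound 1 to compound 3, so the number is expected to move back toward that of compound 1, leaving a basic six-membered ring on a chain, by an expected step of a 3.2-fold higher number from compound 3 to compound 4 (0.50 log units; beyond the scatter). The estimate for compound 4 is 1400 nM, within a range of 600 nM to 3500 nM.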

Compound 4, half-maximal inhibitory concentration: 460 nM
The estimate for compound 4 lay 3.0-fold (0.48 log units) above the measured number; measured number below the stated range.
By their numbers in this assay, from the lowest: compounds 3, 4 and 2 (each within the scatter of the next); then compound 1.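

In this assay, swapping the triazole diol chain for the piperazine chain leaves the number in place (a 1.0-fold higher number from compound 3 to compound 4 (0.02 log units; within the scatter)), and the piperazine chain also stays level with the bare hydrogen (a 1.4-fold lower number from compound 2 to compound 4 (0.16 log units; within the scatter)). A piperazine ring on a chain at this place therefore does not by itself bring the higher number of compound 1, and the remaining difference is a real one (a 3.7-fold lower number from compound 1 to compound 4 (0.57 log units; beyond the scatter)), though in this pair it combines a ring methyl with one more chain carbon. Nothing measured here gives a reason for these numbers.

The compounds shown do not separate the ring methyl from the extra chain carbon. They also leave open whether a morpholine ring, a dimethylamine or a shorter chain on the same nitrogen would behave like the piperazine chain of compound 4 or like the longer chain of compound 1.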